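Ring-substituent swap on the piperazine amide series

The source may report more compounds than this note shows. Statements on the series, on what has been measured and on what is new or still open speak of the compounds shown alone.

Compound 1 `CC1CC(=O)N(CC(=O)N2CCN(c3cccc(Cl)c3)CC2)C1=O`: 100 mg/kg
Compound 2 `Cc1ccccc1N1CCN(C(=O)CN2C(=O)CC(C)C2=O)CC1`: 300 mg/kg

In a functional assay on the whole organism (strain CD1) with Mus musculus as the target, in the maximal electroshock model, with a stated time of 0.5 h (on this read-out lower numbers stand for an effect already at smaller amounts and higher numbers for an effect only at larger amounts of compound), compound 2 stands highest of the two numbers measured; compound 1 gives the lower number, the step of a 3.0-fold higher number from compound 1 to compound 2 (0.48 log units; beyond the scatter) separating them. On these data alone, compound 3 `Cc1cccc(N2CCN(C(=O)CN3C(=O)CC(C)C3=O)CC2)c1` is untested and differs from compound 2 only in the group on the ring nitrogen: 3-methylphenyl in place of 2-methylphenyl on an amine nitrogen in a ring. For the measured compounds named here, the only measured step that bears on this change is a 3.0-fold higher number from compound 1 to compound 2 (0.48 log units; beyond the scatter), which also swapped the aryl group on that nitrogen and was modest. Compound 3 is therefore expected to move back toward the number of compound 1, by a 2.0-fold lower number from compound 2 to compound 3 (0.30 log units; within the scatter), giving an estimated 150 mg/kg with a range from 50 mg/kg to 300 mg/kg.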

Compound 3, minimum effective dose: 300 mg/kg
Beside the measured number, compound 3's estimate is 2.0-fold (0.30 log units) below it; the range from low to high includes it.
By their numbers in this assay, from the lowest: compound 1; then compounds 2 and 3 (each within the scatter of the next).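

Read in this assay, the step of no change at the digits printed from compound 2 to compound 3 (within the scatter) shows that 3-methylphenyl and 2-methylphenyl on this amine nitrogen cannot be told apart. The step of a 3.0-fold higher number from compound 1 to compound 3 (0.48 log units; beyond the scatter) separates the exchange of chloro for methyl from the change of place that the earlier step carried with it, and the gap to compound 1 remains. No measurement shown gives a reason for this. Open, on these data alone, is whether a fluoro or methoxy group on the same phenyl ring would match compound 1 or the two methyl compounds, and whether 2-chlorophenyl would match 3-chlorophenyl.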